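The source may report more compounds than this note shows. Statements on the series, on what has been measured and on what is new or still open speak of the compounds shown alone.

Working notes on the series. All three measured compounds share one core and differ only in the aryl group attached next to the ring nitrogen. Compound 1 `CC(C(=O)NCc1ccc(C(F)(F)F)nc1-c1cccc(Cl)c1)c1ccc(NS(C)(=O)=O)c(F)c1` gives 0.5 nM in an assay on CHO cells for antagonist activity at transient receptor potential cation channel subfamily V member 1 (Homo sapiens), read by FLIPR; on this read-out lower numbers stand for stronger inhibition and higher numbers for weaker inhibition. Compound 2 `CC(C(=O)NCc1ccc(C(F)(F)F)nc1-c1ccc(N(C)C)cc1)c1ccc(NS(C)(=O)=O)c(F)c1` gives 3.2 nM in this assay. Compound 3 `CC(C(=O)NCc1ccc(C(F)(F)F)nc1-c1ccc(F)c(Cl)c1)c1ccc(NS(C)(=O)=O)c(F)c1` gives 0.2 nM in this assay, the lowest number of the three: compound 1 lies nearest, a 2.5-fold lower number from compound 1 to compound 3 (0.40 log units; beyond the scatter), and compound 2 furthest, a 16-fold lower number from compound 2 to compound 3 (1.20 log units; beyond the scatter).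

Compound 4 `COc1ccc(-c2nc(C(F)(F)F)ccc2CNC(=O)C(C)c2ccc(NS(C)(=O)=O)c(F)c2)cc1OC` is the next step from compound 3: 3,4-dimethoxyphenyl in place of 3-chloro-4-fluorophenyl on an aromatic carbon. The entering group carries two hydrogen-bond acceptors and no halogen, where the leaving group carried two halogens and no acceptor. Going by the values given here, the steps that bear on this are those in which halogen-bearing phenyls were exchanged against a phenyl with a nitrogen substituent: a 6.4-fold higher number from compound 1 to compound 2 (0.81 log units; beyond the scatter) and a 16-fold lower number from compound 2 to compound 3 (1.20 log units; beyond the scatter), both beyond the scatter, the second large. The halogen-only change a 2.5-fold lower number from compound 1 to compound 3 (0.40 log units; beyond the scatter) was modest. Among the compounds with values here, no measured compound carries a methoxy group, so the expectation rests on the dimethylamino analogy alone.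

On that basis a higher number is expected for compound 4 in this assay, with a large step, a 15-fold higher number from compound 3 to compound 4 (1.18 log units; beyond the scatter). Compound 4 is estimated at 3 nM, within 0.8 nM to 12 nM.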

Compound 4, inhibition constant: 25.6 nM
For compound 4 the middle estimate is 8.5-fold (0.93 log units) below the measured one; the measured number lies above the stated range.
By their numbers in this assay, from the lowest: compound 3; then compound 1; then compound 2; then compound 4.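

At this place, on an aromatic carbon next to the ring nitrogen, 3,4-dimethoxyphenyl now gives the highest number of the series in this assay, and the 4-(dimethylamino)phenyl compound no longer marks the upper end: the step between these two is an 8.0-fold higher number from compound 2 to compound 4 (0.90 log units; beyond the scatter). Against the halogen-bearing phenyls the exchange is far larger, with a 130-fold higher number from compound 3 to compound 4 (2.11 log units; beyond the scatter) and a 51-fold higher number from compound 1 to compound 4 (1.71 log units; beyond the scatter), so the position separates these aryl groups over a wider span than the first three compounds showed, and in this set of four the two chlorine-bearing phenyls both stand below the two phenyls without halogen, with no compound going against that order. Nothing available on these compounds explains the size of these steps or separates the contributions of the two methoxy groups and the loss of the two halogens.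

Open, as far as these compounds go, is whether both methoxy groups are needed for the rise, or whether a phenyl with a single methoxy group would already show it. Also open, from the compounds shown here alone, is where an unsubstituted phenyl, a hydroxyphenyl or a pyridine ring would fall in this order.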